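The compounds below may be only part of what the source reports. "The series", "measured", "known", "first", "only" and "open" are said of these compounds alone.

Measured compounds in this study:
compound 1, `COc1cccc(CNCCCNS(=O)(=O)c2cc(C(F)(F)F)cc(C(F)(F)F)c2)c1`, with 6400 nM in a functional assay on Capan-2 cells (Homo sapiens) for inhibition, read by MTT assay, with a stated time of 72 h; on this read-out lower numbers stand for stronger inhibition of growth and higher numbers for weaker inhibition of growth;
compound 2, `O=S(=O)(NCCCNCc1cccc(Cl)c1)c1cc(C(F)(F)F)cc(C(F)(F)F)c1`, with 8000 nM;
compound 3, `O=S(=O)(NCCCNCc1ccccc1Cl)c1cc(C(F)(F)F)cc(C(F)(F)F)c1`, with 13000 nM.

Compound 3 gives the highest of the three numbers. Its nearest neighbour is compound 2, a step of a 1.6-fold higher number from compound 2 to compound 3 (0.21 log units; within the scatter), while the step from compound 1 is a 2.0-fold higher number from compound 1 to compound 3 (0.31 log units; beyond the scatter), a modest one. Compound 4, `CN(CCCNS(=O)(=O)c1cc(C(F)(F)F)cc(C(F)(F)F)c1)Cc1ccccc1`, is not yet measured. It differs from compound 3 by benzyl(methyl)amino in place of (2-chlorobenzyl)amino on a saturated chain carbon, three bonds along the chain from a sulfonamide nitrogen. The measured steps that bear on this bear on it only in part: both concern a change on the group attached to the saturated chain carbon bound to an amine nitrogen, and both were small, a 2.0-fold higher number from compound 1 to compound 3 (0.31 log units; beyond the scatter) and a 1.6-fold higher number from compound 2 to compound 3 (0.21 log units; within the scatter). Going by the values given here, no measured pair shows what a benzyl(methyl)amino in place of a (2-chlorobenzyl)amino does, so the direction is open. The size is expected to be small, with a step of a 1.3-fold lower number from compound 3 to compound 4 (0.11 log units; within the scatter) estimated. Compound 4 is therefore expected to give about 10000 nM, with a range from 4000 nM to 25000 nM.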

Compound 4, concentration for 50% growth inhibition: 46000 nM
Estimate against measurement, compound 4: 4.6-fold (0.66 log units) below; the measured number lies above the stated range.
By their numbers in this assay, from the lowest: compounds 1, 2 and 3 (each within the scatter of the next, the first and the last beyond it); then compound 4.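

In this assay, going by these compounds alone, the change to benzyl(methyl)amino gives a 3.5-fold higher number from compound 3 to compound 4 (0.55 log units; beyond the scatter) and a 5.8-fold higher number from compound 2 to compound 4 (0.76 log units; beyond the scatter) and a 7.2-fold higher number from compound 1 to compound 4 (0.86 log units; beyond the scatter); among the earlier compounds only the step between compound 1 and compound 3 was beyond the scatter, and that one only just. This place on the chain therefore responds to the amino group itself, and compound 4, with no hydrogen-bond donor in the entering group, gives a higher number than each compound whose group has one. No measurement at hand accounts for this step.

The change adds a methyl on the amine nitrogen and leaves the ring without chloro or methoxy, and the compounds shown do not separate these two parts. Plain benzylamino and (2-chlorobenzyl)(methyl)amino would each isolate one part, and an ethyl on that nitrogen remains open as well.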